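Chalcone analogs in a keratinocyte proliferation assay

The compounds below may be only part of what the source reports. "The series", "measured", "known", "first", "only" and "open" are said of these compounds alone.

Measured compounds:
- compound 1, `COc1cc(O)c(C(=O)/C=C/c2ccc(F)cc2)c(OC)c1`: "not active" (no number reported)
- compound 2, `COc1cccc(/C=C/C(=O)c2c(OC)cc(OC)cc2OC)c1`: 0%
- compound 3, `COc1cc(O)c(C(=O)/C=C/c2ccccc2OC)c(OC)c1`: 29%

In a functional assay on HaCaT cells (Homo sapiens), read by fluorescence and BrdU incorporation, with a stated time of 48 h, tested at 25 uM (a higher number here means a weaker effect of the compound at the concentration tested, a lower number a stronger effect), compound 2 gives 0%. This is the lowest of the two numbers reported; compound 3 gives 29%, a higher reading, and the gap between compound 2 and compound 3 lies beyond the usual scatter. For compound 1 the result was reported as "not active" (no number reported), with no number attached, so compound 1 cannot be placed on the same scale as the other two.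

Compound 4, `COc1cc(OC)c(C(=O)/C=C/c2ccc(Cl)cc2)c(OC)c1`, has not yet been measured in this assay. It differs from compound 2 in one place: 4-chlorophenyl in place of 3-methoxyphenyl on a double-bonded chain carbon bound to a double-bonded chain carbon. The core of compound 4 carries the same three methoxy groups as the core of compound 2. For the measured compounds named here, no step between two measured compounds matches this change, so there is no measured step to lean on. Given that compound 2 sits at the low end with 0%, a small step upward from compound 2 to compound 4 in this assay is expected, of the size a number 10 percentage points higher from compound 2 to compound 4 (within the scatter), which may or may not exceed the scatter. The estimate for compound 4 is 10%, in the range from 0% to 35%.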

Compound 4, a percentage reported as activity, at one concentration (the size of the read-out at that concentration, not a potency): 0%
Estimate against measurement, compound 4: 10 percentage points above, within the range that was stated.
By their numbers in this assay, from the lowest: compounds 2 and 4 (each within the scatter of the next); then compound 3.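

In this assay, putting 4-chlorophenyl in place of 3-methoxyphenyl on a double-bonded chain carbon bound to a double-bonded chain carbon gives no change at the digits printed from compound 2 to compound 4 (within the scatter), on the same core with its three methoxy groups. The earlier compounds shown here offered no measured step at this position, and this one shows that, on this core, the reading does not depend on the methoxy group of the leaving 3-methoxyphenyl, since a chlorine-bearing phenyl ring without a hydrogen-bond acceptor serves equally well within the scatter. The two compounds therefore mark this position as one that accepts at least this exchange of one substituted phenyl ring for another, though nothing at hand gives a reason for that outcome.

What the compounds shown leave open is how far that tolerance extends, for instance whether a phenyl ring carrying an amine or a carboxylic acid at this chain carbon would keep the same reading. They also leave open whether a cyclohexyl group, with no aromatic ring at all, would do so on the same core.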